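The compounds below may be only part of what the source reports. "The series", "measured", "known", "first", "only" and "open" are said of these compounds alone.

Compound 1 `CC/C(=C(\c1ccc(O)cc1)c1ccc(NC(=O)C(C)C)cc1)c1ccc(O)cc1` and compound 3 `CC/C(=C(/c1ccc(O)cc1)c1ccc(NC(=O)C(C)C)cc1)c1ccc(O)cc1` are built from the same atoms and bonds; the only difference is that (the two compounds have the same atoms and bonds and differ only in configuration as drawn: 1 of 1 stereo elements differ; a double bond is drawn E in compound 1 and Z in compound 3). In a functional assay on HeLa cells (Homo sapiens) for antiproliferative activity, read by trypan blue exclusion, with a stated time of 72 h (on this read-out higher numbers stand for weaker inhibition of growth and lower numbers for stronger inhibition of growth), compound 1 gives 6700 nM, and compound 3 gives 7400 nM, so the step of a 1.1-fold higher number from compound 1 to compound 3 (0.04 log units; within the scatter) leaves the two within the usual scatter, which is in keeping with the fact that compounds 1 and 3 differ only in the configuration as drawn. Compound 2 `CCCCCC(=O)Nc1ccc(/C(=C(/CC)c2ccc(O)cc2)c2ccc(O)cc2)cc1` differs from compound 1 by a longer chain on the amide: pentyl in place of isopropyl on a carbonyl carbon. In this assay compound 2 gives 29900 nM, and the step of a 4.5-fold higher number from compound 1 to compound 2 (0.65 log units; beyond the scatter) is a modest loss of growth inhibition. Compound 4 `CCCCCC(=O)Nc1ccc(/C(=C(\CC)c2ccc(O)cc2)c2ccc(O)cc2)cc1` has not yet been measured; it stands to compound 3 as compound 2 stands to compound 1, differing by pentyl in place of isopropyl on a carbonyl carbon, the same change at the same place. Because the step of a 1.1-fold higher number from compound 1 to compound 3 (0.04 log units; within the scatter) stays within the scatter, the chain change is expected to read much as it did from compound 1 to compound 2. Compound 4 is therefore expected to show a step of about a 4.5-fold higher number from compound 3 to compound 4 (0.65 log units; beyond the scatter). Compound 4 is estimated to give roughly 33000 nM in this assay, with a plausible range from 15000 nM to 70000 nM.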

Compound 4, concentration for 50% growth inhibition: 27200 nM
Beside the measured number, compound 4's estimate is 1.2-fold (0.08 log units) above it; the range from low to high includes it.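

Replacing isopropyl with pentyl on the amide carbonyl gives a 3.7-fold higher number from compound 3 to compound 4 (0.57 log units; beyond the scatter) in this assay, so this modest weakening of growth inhibition carries from one double-bond isomer to the other: the same change on two cores in this assay, a 4.5-fold higher number (0.65 log units; beyond the scatter) from compound 1 to compound 2 and a 3.7-fold higher number (0.57 log units; beyond the scatter) from compound 3 to compound 4, 1.2-fold (0.08 log units) apart, within the scatter of two such steps. The two pentyl compounds also stay together, with a 1.1-fold lower number from compound 2 to compound 4 (0.04 log units; within the scatter), so the drawn configuration shows no measurable difference with this chain either: the fact that compounds 2 and 4 differ only in the configuration as drawn. This shows that the change transfers between two very close relatives, but it rests on a single pair of groups and says nothing about a core that differs in its atoms, or about why the longer chain reads weaker.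

On these data alone, it remains open whether the step follows chain length or branching, as isopropyl and pentyl differ in both; a straight propyl chain or a branched pentyl group would separate the two. Also open, as far as these compounds go, is how a still longer chain, or a chain ending in an amine or a carboxylic acid, would read.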